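Replacing the trifluoromethoxy end of compound 3

The compounds below may be only part of what the source reports. "The series", "measured", "known", "first", "only" and "open" are said of these compounds alone.

In a functional assay on SiHa cells (Homo sapiens) for inhibition, read by sulforhodamine B assay (on this read-out lower numbers stand for stronger inhibition of growth and higher numbers for weaker inhibition of growth), compound 1 `FC(F)(F)Oc1ccc(-c2ccc(-c3ccc(-c4nc5ccccc5[nH]4)cc3)cc2)cc1` gives 38400 nM, compound 2 `COc1ccc(-c2ccc(-c3ccc(-c4nc5ccccc5[nH]4)cc3)cc2)cc1` gives 2760 nM and compound 3 `Oc1cccc2[nH]c(-c3ccc(-c4ccc(-c5ccc(OC(F)(F)F)cc5)cc4)cc3)nc12` gives 8410 nM. Compound 3 therefore holds the middle of the three numbers, above compound 2 and below compound 1. Compound 4 `Oc1cccc2[nH]c(-c3ccc(-c4ccc(-c5cccc(Cl)c5)cc4)cc3)nc12` keeps the hydroxy group of compound 3 and differs elsewhere: 3-chlorophenyl in place of 4-(trifluoromethoxy)phenyl on an aromatic carbon. For the measured compounds named here, two measured steps bear on this change, though neither matches it. Methyl in place of trifluoromethyl on an oxygen on an aromatic ring gave a 14-fold lower number from compound 1 to compound 2 (1.14 log units; beyond the scatter), a large step showing that altering this group can move the number a long way. Hydroxy in place of hydrogen on an aromatic carbon gave a 4.6-fold lower number from compound 1 to compound 3 (0.66 log units; beyond the scatter), a modest step that compound 4 retains, so it only sets the starting point. Going by the values given here, no measured compound carries chlorine, which leaves the size uncertain. A small move to a lower number is expected, with the estimated step being a 2.2-fold lower number from compound 3 to compound 4 (0.35 log units; beyond the scatter). For compound 4 the expected value is 3800 nM, within an estimated range from 1100 nM to 13000 nM.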

Compound 4, concentration for 50% growth inhibition: 8400 nM
Estimate against measurement, compound 4: 2.2-fold (0.34 log units) below; the measured number falls inside the stated range.
By their numbers in this assay, from the lowest: compound 2; then compounds 4 and 3 (each within the scatter of the next); then compound 1.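

In this assay, replacing the group on this aromatic carbon, para to a large group, gives a 1.0-fold lower number from compound 3 to compound 4 (0.00 log units; within the scatter), so 3-chlorophenyl and 4-(trifluoromethoxy)phenyl cannot be told apart on the hydroxy-bearing core. The earlier compounds shown here showed that a small edit within this group can matter, with a 14-fold lower number from compound 1 to compound 2 (1.14 log units; beyond the scatter); this pair adds that exchanging the whole group for one with fewer heavy atoms and no hydrogen-bond acceptor can leave the number within the scatter. Nothing shown here explains this match.

Whether 4-methoxyphenyl would give a lower number on the hydroxy-bearing core remains open, since the only methoxy compound shown lacks the hydroxy group. As far as these compounds go, it is also open how the number would respond to an amine or a carboxylic acid on this terminal aromatic ring.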